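Swapping the aryl group on the shared core: compound 3

The compounds below may be only part of what the source reports. "The series", "measured", "known", "first", "only" and "open" are said of these compounds alone.

Measured compounds:
Compound 1, `N#CC1=C(N)N(c2ccc(S(N)(=O)=O)cc2)C2=C(C(=O)CCC2)C1/C=C/c1ccccc1`: > 100 ug/mL
Compound 2, `COc1ccc(C2C(C#N)=C(N)N(c3ccc(S(N)(=O)=O)cc3)C3=C2C(=O)CCC3)cc1`: 25 ug/mL

In a functional assay on Ehrlich cells (Mus musculus) for antiproliferative activity, read by trypan blue exclusion, with a stated time of 2 h (a higher number here means a weaker inhibitor, a lower number a stronger inhibitor), compound 1 reaches only a limit, > 100 ug/mL, and no number. Going by the values given here, compound 2 gives the one actual number here, 25 ug/mL, so compound 2 stands as the sole fixed point among the two values. Among the compounds with values here, the single measured step, an at least 4.0-fold lower number from compound 1 to compound 2 (0.60 log units; beyond the scatter), shows that the group on the saturated ring carbon of the shared core matters, and the limit of > 100 ug/mL in this assay, at which 1 of the 2 values shown sits, is part of that step.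

Compound 3, `N#CC1=C(N)N(c2ccc(S(N)(=O)=O)cc2)C2=C(C(=O)CCC2)C1c1c(O)ccc2ccccc12`, differs from compound 2 by 2-hydroxynaphthalen-1-yl in place of 4-methoxyphenyl on a saturated ring carbon. Within the data shown here, no measured step swaps one aromatic group for another at this position, so the step from compound 1 to compound 2 bears on compound 3 only in showing that this position is sensitive; it gives no direction for a naphthyl group. The expected step is therefore a 1.2-fold higher number from compound 2 to compound 3 (0.08 log units; within the scatter), with wide uncertainty. Compound 3 is estimated at 30 ug/mL, between 8 ug/mL and 100 ug/mL.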

Compound 3, half-maximal inhibitory concentration: > 100 ug/mL
Compound 3: only a limit was reported (the forecaster's own chance of this, stated with the estimate: 25%); middle value at least 3.3-fold (0.52 log units) from the limit.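

In this assay, replacing 4-methoxyphenyl with 2-hydroxynaphthalen-1-yl on the saturated ring carbon gives an at least 4.0-fold higher number from compound 2 to compound 3 (0.60 log units; beyond the scatter). Going by these compounds alone, the earlier pair showed only that an aromatic group and 2-phenylethenyl at this carbon can differ; this step shows that exchanging one aromatic group for another can also cost activity, so having an aromatic group here does not by itself give the number seen for compound 2. For compound 3, > 100 ug/mL is a limit and not a number, so the full size of the step stays unknown, the step from compound 1 to compound 3 cannot be read, and the series still has only one fixed number: the limit of > 100 ug/mL in this assay, at which 2 of the 3 values shown sit.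

The change from compound 2 to compound 3 alters the ring system and the oxygen-bearing group at once, so the data cannot say which of the two matters. A naphthyl group without the hydroxyl, or a phenyl ring carrying a hydroxyl in place of the methoxy, would separate these two changes, while a plain phenyl or an aromatic ring bearing an amine would show how far this carbon tolerates other groups.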